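Carboxy-Methylethylamino in Place of Hydroxy at the Benzylic Carbon

The compounds below may be only part of what the source reports. "The series", "measured", "known", "first", "only" and "open" are said of these compounds alone.

compound 1 `COc1ccc(/C=C\c2cc(OC)c(OC)c(OC)c2)cc1OCc1ccc(CNCCN(C)C)cc1`: 4400 nM
compound 2 `COc1ccc(/C=C\c2cc(OC)c(OC)c(OC)c2)cc1OCc1ccc(CO)cc1`: 2400 nM

In a functional assay on HepG2 cells (Homo sapiens) for antiproliferative activity, read by CCK-8 assay, with a stated time of 48 h (on this read-out higher numbers stand for weaker inhibition and lower numbers for stronger inhibition), compound 2 gives 2400 nM, the lower of the two numbers shown, yet its distance from compound 1 at 4400 nM is within the scatter. Compound 3 `COc1ccc(/C=C\c2cc(OC)c(OC)c(OC)c2)cc1OCc1ccc(CNC(C)(C)C(=O)O)cc1` differs from compound 2 by (1-carboxy-1-methylethyl)amino in place of hydroxy on a saturated chain carbon bound to an aromatic carbon. Among the compounds with values here, the one measured step at this same place, a 1.8-fold lower number from compound 1 to compound 2 (0.26 log units; within the scatter), exchanged one amino group for hydroxy and stayed within the scatter, so no step beyond the scatter is expected here either, with the estimate a 1.5-fold higher number from compound 2 to compound 3 (0.16 log units; within the scatter). Compound 3 is therefore expected at 3500 nM, within 1500 nM to 9000 nM.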

Compound 3, half-maximal inhibitory concentration: 6500 nM
For compound 3 the middle estimate is 1.9-fold (0.27 log units) below the measured one; the measured number falls inside the stated range.
By their numbers in this assay, from the lowest: compounds 2, 1 and 3 (each within the scatter of the next, the first and the last beyond it).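

In this assay, within the data shown here, (1-carboxy-1-methylethyl)amino in place of hydroxy on a saturated chain carbon bound to an aromatic carbon gives the first step at this place that lies beyond the scatter, modest in size (a 2.7-fold higher number from compound 2 to compound 3 (0.43 log units; beyond the scatter)). Exchanging 2-(dimethylamino)ethyl for 1-carboxy-1-methylethyl on the amine nitrogen does not separate the two amines (a 1.5-fold higher number from compound 1 to compound 3 (0.17 log units; within the scatter)). Nothing available bears on the reason for either step. As far as these compounds go, whether a primary amine, a methyl ether or a carboxylic acid without the amine nitrogen at this carbon would stay close to compound 2 remains open.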